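The source may hold more compounds than are shown below. What is called first, only, known or untested is meant among the compounds shown, and "the series" means these compounds.

In a functional assay on BGC-823 cells (Homo sapiens) for antiproliferative activity, read by MTT assay, tested at 5 uM (a lower number here means a weaker effect, a higher number a stronger effect of the compound at the concentration tested), compound 1 `COc1ccc(/C=N/NC(=O)c2cc(OC)c(OC)c(OC)c2)c(OC)c1` gives 3.6%, compound 2 `COc1cc(C(=O)N/N=C/c2ccc(F)c(F)c2)cc(OC)c1OC` gives 51.9%, and compound 3 `COc1cc(C2=NN(C(C)=O)C(c3ccc(F)c(F)c3)O2)cc(OC)c1OC` gives 21.6%. Compound 3 therefore holds the second highest of the three numbers: compound 1 is its nearest neighbour, lying lower by a gap beyond the scatter, while compound 2 stands furthest away, higher by a gap also beyond the scatter. Compound 4 `COc1cc(C2=NN(C(C)=O)C(c3ccc(C(F)(F)F)cc3)O2)cc(OC)c1OC` differs from compound 3 in a single place: 4-(trifluoromethyl)phenyl in place of 3,4-difluorophenyl on a saturated ring carbon. Among the compounds with values here, no measured pair shows this exchange, so its effect cannot be read from the data, and the step in this assay is expected to be none beyond the scatter in either direction. The step of a number 2.4 percentage points higher from compound 3 to compound 4 (within the scatter) is accordingly expected to be small. Compound 4 is estimated at 24%, within a range from 5% to 48%.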

Compound 4, a percentage reported as inhibition, at one concentration (the size of the read-out at that concentration, not a potency): 3.4%
Compound 4: middle estimate off by 20.6 percentage points, on the high side, and the stated range ends above it.
By their numbers in this assay, from the lowest: compounds 4 and 1 (each within the scatter of the next); then compound 3; then compound 2.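

In this assay, 4-(trifluoromethyl)phenyl in place of 3,4-difluorophenyl on the saturated ring carbon gives a number 18.2 percentage points lower from compound 3 to compound 4 (beyond the scatter), so the read-out depends on which fluorinated phenyl sits at this position. Within the data shown here, this is the first measured change at this place, and it shows that this exchange alone, with the rest of the molecule held constant, moves the number beyond the scatter. No available evidence explains the step. Going by these compounds, it remains open how a phenyl carrying an amine or a carboxylic acid would behave at this carbon, and whether the same exchange on compound 2 would give a step of similar size.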